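Cytotoxicity notes on a bicyclic nucleoside analogue series

The compounds below may be only part of what the source reports. "The series", "measured", "known", "first", "only" and "open" are said of these compounds alone.

Measured compounds:
- compound 1, `CC(C)C(Nc1nc(Cl)nc2c1ncn2[C@H]1[C@H](O)[C@H](O)[C@]2(CO)C[C@H]12)C(C)C`: > 100000 nM
- compound 2, `CSc1nc(N[C@@H](C2CC2)C(C)(C)O)c2ccn([C@H]3[C@H](O)[C@H](O)[C@]4(CO)C[C@H]34)c2n1`: > 100000 nM
- compound 3, `NCCCNC(=O)[C@@]12C[C@@H]1[C@@H](n1cnc3c(NC(C4CC4)C4CC4)nc(Cl)nc31)[C@H](O)[C@@H]2O`: 50000 nM

In an ADME assay on Vero 76 cells (Chlorocebus sabaeus) for cytotoxicity, read by neutral red uptake (on this read-out higher numbers stand for lower toxicity in this test and lower numbers for higher toxicity in this test), compound 1 reaches only a limit of the assay, > 100000 nM. Compound 2 likewise sits at a limit in this assay, > 100000 nM. Compound 3 gives a number in this assay, 50000 nM. Two of the three values shown thus sit at the same limit, (the limit of > 100000 nM in this assay, at which 2 of the 3 values shown sit), and compound 1 is one of them, so its standing relative to the others cannot be ordered.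

Compound 4, `CC(C)(C)[C@H](Nc1nc(Cl)nc2c1ncn2[C@H]1[C@H](O)[C@H](O)[C@]2(CO)C[C@H]12)C1CC1`, is not yet measured. It differs from compound 1 by 1-cyclopropyl-2,2-dimethylpropyl in place of 1-isopropyl-2-methylpropyl on a nitrogen on an aromatic ring. Going by the values given here, no measured pair isolates such a change. The step from compound 1 to compound 4 is expected to be a number no higher from compound 1 to compound 4 (the limit leaves the size open), that is, none beyond the scatter. Compound 4 is therefore expected to give about 100000 nM in this assay, within 30000 nM to 300000 nM.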

Compound 4, half-maximal cytotoxic concentration: > 100000 nM
Compound 4 ended at the assay's limit (the forecaster's own chance of this, stated with the estimate: 65%); the middle value sits exactly at the limit.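

Compound 1 and compound 4 both sit at a limit of this assay, so no step between them can be read: the limit of > 100000 nM in this assay, at which 3 of the 4 values shown sit.

Going by these compounds, whether 1-cyclopropyl-2,2-dimethylpropyl in place of 1-isopropyl-2-methylpropyl changes the half-maximal cytotoxic concentration at all stays open.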